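A Spiro Amine in Place of the Dimethylmorpholine

The source may report more compounds than this note shows. Statements on the series, on what has been measured and on what is new or still open speak of the compounds shown alone.

The measured compounds, read in a physicochemical assay for solubility, read by spectrophotometry, in phosphate buffer, with a stated time of 2 h, at pH 7.4; on this read-out higher numbers stand for higher solubility and lower numbers for lower solubility:
Compound 1 `COc1ccc2[nH]c(C(=O)N3CC(=O)N(Cc4ccccc4)[C@@H](CN4CCC5(CC4)CC5)C3)cc2c1` gives 28200 nM.
Compound 2 `COc1ccc2[nH]c(C(=O)N3CC(=O)N(Cc4ccccc4)[C@@H](CN4CCC(OC)CC4)C3)cc2c1` gives > 25000 nM, which is a limit of the assay and not a number.
Compound 3 `COc1ccc2[nH]c(C(=O)N3CC(=O)N(Cc4ccccc4)[C@@H](CN4[C@H](C)COC[C@@H]4C)C3)cc2c1` gives > 100000 nM, again a limit of the assay and not a number.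

Compound 3 thus stands only at a limit in this assay; no exact number is known for it. Compound 4 `COc1ccc2[nH]c(C(=O)N3CC(=O)N(Cc4ccccc4)[C@@H](CN4CC5(CCC5)C4)C3)cc2c1` is unmeasured and differs from compound 3 by a group of 7 heavy atoms (6 carbon, 1 nitrogen; one four-membered non-aromatic ring of carbon only, one four-membered non-aromatic ring with 1 hetero atom) in place of a group of 8 heavy atoms (6 carbon, 1 nitrogen, 1 oxygen; one six-membered non-aromatic ring with 2 hetero atoms), on a saturated chain carbon bound to a saturated ring carbon. Within the data shown here, two measured steps touch this position. The step of an at least 3.5-fold higher number from compound 1 to compound 3 (0.54 log units; beyond the scatter) shows the 3,5-dimethylmorpholin-4-yl group reading higher than a group built from a three-membered ring of carbon only and a six-membered ring with 1 hetero atom, while a step that the two limits leave unreadable from compound 2 to compound 3 has no readable size. The entering group of compound 4, built from a four-membered ring of carbon only and a four-membered ring with 1 hetero atom, resembles the group of compound 1 more than it resembles 3,5-dimethylmorpholin-4-yl. Because compound 1 gives 28200 nM with such a group, compound 4 is expected to move by an at least 3.3-fold lower number from compound 3 to compound 4 (0.52 log units; beyond the scatter). Compound 4 is therefore estimated at about 30000 nM, within 10000 nM to 100000 nM.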

Compound 4, solubility: 60700 nM
Compound 4: the middle estimate sits 2.0-fold (0.31 log units) below what was measured; low and high end bracket the measured number.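

In this assay, the group built from a four-membered ring of carbon only and a four-membered ring with 1 hetero atom gives a second exact number at this position, on a saturated chain carbon bound to a saturated ring carbon. The measured step of a 2.2-fold higher number from compound 1 to compound 4 (0.33 log units; beyond the scatter) shows that two groups without oxygen can differ beyond the scatter here. Replacing 3,5-dimethylmorpholin-4-yl gives an at least 1.6-fold lower number from compound 3 to compound 4 (0.21 log units; that floor lies within the scatter), a floor that rests on a limit of the assay for compound 3 and so does not show a change beyond the scatter.

The step from compound 2 to compound 4 cannot be read, and neither compound 2 nor compound 3 has an exact number: the limit of > 25000 nM in this assay, at which 1 of the 4 values shown sits. The compounds shown also leave open how this position would read with a carboxylic acid or a hydroxyl on the four-membered ring of carbon only.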